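The source may report more compounds than this note shows. Statements on the series, on what has been measured and on what is new or still open speak of the compounds shown alone.

Compound 1 `FC(F)(F)c1ccc(C2=NN(C(=S)Nc3ccccc3)C(c3ccc4c(c3)OCCO4)C2)cc1` carries a 4-(trifluoromethyl)phenyl group on the carbon with a double bond to nitrogen of the shared core. In a functional assay on HT-29 cells (Homo sapiens) for antiproliferative activity, read by MTT assay, with a stated time of 48 h (a lower number here means a stronger inhibitor of growth, a higher number a weaker inhibitor of growth), compound 1 gives 97500 nM, the highest of the two numbers in hand. Compound 3 `COc1cccc(C2=NN(C(=S)Nc3ccccc3)C(c3ccc4c(c3)OCCO4)C2)c1` gives 2920 nM in this assay, a move of a 33-fold lower number from compound 1 to compound 3 (1.52 log units; beyond the scatter). Compound 2 `S=C(Nc1ccccc1)N1N=C(c2ccccc2Br)CC1c1ccc2c(c1)OCCO2` reaches only a limit of the assay, > 200000 nM. Accordingly the step is an at least 2.0-fold higher number from compound 1 to compound 2 (0.31 log units; beyond the scatter), and an at least 68-fold lower number from compound 2 to compound 3 (1.83 log units; beyond the scatter); the limit of > 200000 nM in this assay, at which 1 of the 3 values shown sits, caps what can be said of compound 2 beyond that.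

Compound 4 `S=C(Nc1ccccc1)N1N=C(c2ccc(Cl)c(Cl)c2)CC1c1ccc2c(c1)OCCO2` differs from compound 1 in one place: 3,4-dichlorophenyl in place of 4-(trifluoromethyl)phenyl on a carbon with a double bond to nitrogen. Both measured steps replace the same aryl group and so bear on this one: the bromophenyl variant moved the number up, at least modestly, while the methoxyphenyl variant brought it down strongly. The 3,4-dichlorophenyl group matches neither of these patterns, so no large step is expected in either direction, and the step from compound 1 to compound 4 is estimated as a 1.6-fold lower number from compound 1 to compound 4 (0.21 log units; within the scatter), within or near the scatter. Compound 4 is therefore expected to give about 60000 nM in this assay, with a range from 15000 nM to 200000 nM.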

Compound 4, concentration for 50% growth inhibition: 95300 nM
Estimate against measurement, compound 4: 1.6-fold (0.20 log units) below, within the range that was stated.
By their numbers in this assay, from the lowest: compound 3; then compounds 4 and 1 (each within the scatter of the next). At a limit, above all of these: compound 2.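

In this assay, the 3,4-dichlorophenyl and 4-(trifluoromethyl)phenyl groups cannot be told apart at this position, on the carbon with a double bond to nitrogen: a 1.0-fold lower number from compound 1 to compound 4 (0.01 log units; within the scatter). Compound 3 now stands apart from two differently substituted phenyl groups rather than one, with a 33-fold higher number from compound 3 to compound 4 (1.51 log units; beyond the scatter), so the low number of the 3-methoxyphenyl group is shared by neither. The remaining step rests on the limit of compound 2, which is not a number, and it reads only as a bound, an at least 2.0-fold lower number from compound 2 to compound 4 (0.32 log units; beyond the scatter), with nothing further to be said of its size: the limit of > 200000 nM in this assay, at which 1 of the 4 values shown sits.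

Still open, from the compounds shown here alone, is whether the methoxy group itself or its place on the phenyl ring sets compound 3 apart, and what a 3-hydroxyphenyl or 3-aminophenyl group would give at this position. Going by these compounds, whether the same steps hold in any other cell line also stays open.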